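Removing the Nitro Group from Compound 3

A few compounds are considered here, and "the series" means these few. Any claim that something is new, unique, unknown or untested is made for them only; others in the source may bear on it.

Of the compounds shown here, three sharing one core have been measured in a functional assay on RPMI-8226 cells (Homo sapiens) for inhibition; a higher number here means a weaker inhibitor, a lower number a stronger inhibitor. Compound 1 `N#CC1CN1C(=O)Nc1ccc(F)cc1` gives 5900 nM in this assay. Compound 2 `CCOC(=O)c1ccc(NC(=O)N2CC2C#N)cc1` gives 3000 nM in this assay. Compound 3 `N#CC1CN1C(=O)Nc1ccc([N+](=O)[O-])cc1` gives 8600 nM in this assay, the highest of the three numbers; a 1.5-fold higher number from compound 1 to compound 3 (0.16 log units; within the scatter), and a 2.9-fold higher number from compound 2 to compound 3 (0.46 log units; beyond the scatter).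

Compound 4 `N#CC1CN1C(=O)Nc1ccccc1` differs from compound 3 by hydrogen in place of nitro on an aromatic carbon. Going by the values given here, no measured step exchanges a substituent for hydrogen at this position, so the expectation rests on the two steps that lead into compound 3: the one from compound 2 lies beyond the scatter and runs upward when nitro enters, while the one from compound 1 stays within it. Taking nitro away again is therefore expected to lower the number by a small amount, at most a modest one, so that a 1.7-fold lower number from compound 3 to compound 4 (0.24 log units; within the scatter) is the expected step. Compound 4 is estimated at 5000 nM, with a range from 2000 nM to 12000 nM.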

Compound 4, half-maximal inhibitory concentration: 8000 nM
Compound 4: middle estimate off by 1.6-fold (0.20 log units), on the low side, within the range that was stated.
By their numbers in this assay, from the lowest: compounds 2, 1, 4 and 3 (each within the scatter of the next, the first and the last beyond it).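

In this assay, hydrogen on this aromatic carbon gives a direct reading of what the substituent contributes, and a 1.1-fold lower number from compound 3 to compound 4 (0.03 log units; within the scatter) shows that removing nitro leaves the number unchanged within the scatter. Fluoro cannot be told apart from hydrogen either, with a 1.4-fold higher number from compound 1 to compound 4 (0.13 log units; within the scatter) as the step. Ethoxycarbonyl alone stands apart from hydrogen, with a 2.7-fold higher number from compound 2 to compound 4 (0.43 log units; beyond the scatter) lying beyond the scatter though modest in size, so among these four compounds a substituent at this position is not required for inhibition at this level, and only the ester shows a separable gain.

Nothing available here bears on why the ester differs from hydrogen. As far as these compounds go, it remains open whether a carboxylic acid, an amine or a longer ester chain at this position would extend that gain or lose it.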